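The source may hold more compounds than are shown below. What is called first, only, known or untested is meant among the compounds shown, and "the series" means these compounds.

Compound 1 `COC[C@H](C)Oc1cc(Oc2ccc(S(C)(=O)=O)cc2)cc(C(=O)Nc2ccc(C(=O)O)cn2)c1`: -0.4
Compound 2 `COC[C@H](C)Oc1cc(Oc2cc(F)cc(F)c2)cc(C(=O)Nc2nccs2)c1`: 4.1

In a physicochemical assay for lipophilicity (a higher number here means a more lipophilic compound, a lower number a more polar compound), compound 2 stands higher of the two at 4.1. Compound 1 lies far lower at -0.4, a gap well beyond the usual scatter of repeat measurements.

Compound 3 `COC[C@H](C)Oc1cc(Oc2cc(F)cc(F)c2)cc(C(=O)Nc2ccc(C(=O)O)cn2)c1` is built from compound 2 by one structural change, 5-carboxypyridin-2-yl in place of 1,3-thiazol-2-yl on an amide-type nitrogen. Among the compounds with values here, no measured pair differs in only one place, so the size of this step can only be judged indirectly. The best guide is compound 1, which already carries 5-carboxypyridin-2-yl on that nitrogen and gives -0.4, although it also differs from compound 3 elsewhere in the structure. A large fall in this assay, well beyond the scatter, is therefore expected. The expected step is a number 3.10 log units lower from compound 2 to compound 3 (beyond the scatter). For compound 3 the estimated value is 1, with a range of 0.3 to 1.8.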

Compound 3, distribution coefficient: 1.4
Estimate against measurement, compound 3: 0.40 log units below; the range from low to high includes it.
By their numbers in this assay, from the lowest: compound 1; then compound 3; then compound 2.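

In this assay, within the data shown here, 5-carboxypyridin-2-yl in place of 1,3-thiazol-2-yl on the amide-type nitrogen, taken as the only change, gives a number 2.70 log units lower from compound 2 to compound 3 (beyond the scatter), so this position alone accounts for a large share of the wide gap between the two earlier compounds. The gap does not rest on that position alone: 3,5-difluorophenyl in place of 4-(methylsulfonyl)phenyl on an oxygen on an aromatic ring gives a number 1.80 log units higher from compound 1 to compound 3 (beyond the scatter), which makes it a second large step in a different place. No measured evidence on the cause of either step is at hand.

As far as these compounds go, in these compounds the carboxylic acid arrives only together with the pyridine ring, so the share of each in the first step stays open. A pyridin-2-yl group carrying a methyl ester or an amine in place of the acid would separate the two.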